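The source may hold more compounds than are shown below. What is called first, only, known or untested is meant among the compounds shown, and "the series" means these compounds.

Measured in a functional assay on the whole organism with Rattus norvegicus as the target; on this read-out higher numbers stand for an effect only at larger amounts of compound and lower numbers for an effect already at smaller amounts:
- compound 1 `CCOc1ccccc1-c1ncc(-c2nn[nH]n2)c(O)n1`: 0.09 mg/kg
- compound 2 `CC(C)COc1ccccc1-c1ncc(-c2nn[nH]n2)c(O)n1`: 0.1 mg/kg

Among the compounds with values here, of these two numbers, the one for compound 2, 0.1 mg/kg, lies within the scatter of the one for compound 1, so the pair stands level. Compound 3 `Oc1nc(-c2ccccc2OCC2CC2)ncc1-c1nn[nH]n1` is still to be measured in this assay. It carries cyclopropyl in place of isopropyl on a saturated chain carbon bound to an oxygen on an aromatic ring, which turns isobutoxy into cyclopropylmethoxy: cyclopropyl in place of isopropyl on a saturated chain carbon bound to an oxygen on an aromatic ring. Within the data shown here, one measured step bears on this place, a 1.1-fold higher number from compound 1 to compound 2 (0.05 log units; within the scatter), and it stays within the scatter. Among the measured compounds shown here, no measured compound yet has a ring at this place, so that evidence is indirect. The expected change is therefore no change at the digits printed from compound 2 to compound 3 (within the scatter), with no direction and nothing beyond the scatter. For compound 3 the estimated value is 0.1 mg/kg, with an expected range of 0.04 mg/kg to 0.25 mg/kg.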

Compound 3, dose for 50% inhibition: 0.07 mg/kg
The estimate for compound 3 lay 1.4-fold (0.15 log units) above the measured number; measured number inside the range.
By their numbers in this assay, from the lowest: compounds 3, 1 and 2 (each within the scatter of the next).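

Cyclopropyl in place of isopropyl on a saturated chain carbon bound to an oxygen on an aromatic ring gives a 1.4-fold lower number from compound 2 to compound 3 (0.15 log units; within the scatter) and cyclopropyl in place of methyl at that carbon gives a 1.3-fold lower number from compound 1 to compound 3 (0.11 log units; within the scatter) in the same test. Until now only open chains had stood at this place, and in this assay a three-membered ring of carbon only now stands there too, with compound 3 within the scatter of both compound 1 and compound 2. Nothing at hand accounts for this level result.

On these data alone, it remains open whether a larger ring such as cyclohexyl, a longer chain, or a chain ending in an amine or a carboxylic acid would carry the number beyond the scatter. As far as these compounds go, all three compounds share one core, so how this place behaves on any other core also remains open.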